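A few compounds are considered here, and "the series" means these few. Any claim that something is new, unique, unknown or untested is made for them only; others in the source may bear on it.

Compound 1 `CN1CCN(CCCCCn2c3c(c4ccccc42)C(=O)c2c[n+]([O-])c4ccccc4c2C3=O)CC1` and compound 2 `O=C1c2c[n+]([O-])c3ccccc3c2C(=O)c2c1c1ccccc1n2Cc1cn(CC(O)CO)nn1` share the same core and differ only in the group attached to the saturated chain carbon bound to an aromatic nitrogen. In a functional assay on MCF7 cells (Homo sapiens) for cytotoxicity, read by MTT assay, with a stated time of 72 h (a lower number here means a stronger inhibitor, a higher number a weaker inhibitor), compound 1 gives 1260 nM, and compound 2 gives 1110 nM. The step between them, a 1.1-fold lower number from compound 1 to compound 2 (0.06 log units; within the scatter), shows no change beyond the scatter; compound 2 thus sits alongside compound 1 rather than apart from it.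

Compound 3 `O=C1c2c[n+]([O-])c3ccccc3c2C(=O)c2c1c1ccccc1n2CCCCN1CCCCC1` carries a further variation at the same place: 3-(piperidin-1-yl)propyl in place of 1-(2,3-dihydroxypropyl)-1H-1,2,3-triazol-4-yl on a saturated chain carbon bound to an aromatic nitrogen. Within the data shown here, the only step that bears on this change is the one from compound 1 to compound 2, where a chain ending in a ring with one nitrogen was exchanged for the triazole diol without effect, and compound 3 returns to a chain of that earlier kind. A step of no size beyond the scatter is therefore expected, a 1.1-fold higher number from compound 2 to compound 3 (0.03 log units; within the scatter). Compound 3 is estimated at 1200 nM, within 500 nM to 3000 nM.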

Compound 3, half-maximal inhibitory concentration: 150 nM
Beside the measured number, compound 3's estimate is 8.0-fold (0.90 log units) above it; measured number below the stated range.
By their numbers in this assay, from the lowest: compound 3; then compounds 2 and 1 (each within the scatter of the next).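

This position is not indifferent to its group, as the step between compound 1 and compound 2 alone suggested: in this assay there is a 7.4-fold lower number from compound 2 to compound 3 (0.87 log units; beyond the scatter), and also an 8.4-fold lower number from compound 1 to compound 3 (0.92 log units; beyond the scatter), which makes compound 3 the strongest of the three. Ending a chain in a saturated ring is not enough on its own, since compound 1 has such a chain end yet stays within the scatter of compound 2, which carries the triazole diol. Nothing available here explains why the 4-(piperidin-1-yl)butyl group stands apart.

From compound 1 to compound 3, the ring and the chain change together, so their shares in the step cannot be separated. As far as these compounds go, a morpholin-4-yl or diethylamino group on the same chain, or a piperidin-1-yl group on a longer chain, remains open.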